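Shifting the aryl group on the shared core: compound 3

The compounds below may be only part of what the source reports. "The series", "measured", "known", "first", "only" and "open" are said of these compounds alone.

Measured compounds:
compound 1 `C=CCn1c(=O)/c(=C\c2cccc(Cl)c2)[nH]c(=O)/c1=C\c1ccccc1OC` — 4600 nM
compound 2 `C=CCn1c(=O)/c(=C\c2ccc(Cl)c(Cl)c2)[nH]c(=O)/c1=C\c1ccccc1OC` — "not active" (no number reported) (no number reported)

Of the compounds shown here, two sharing one core have been tested in a functional assay on BGC-823 cells (Homo sapiens) for cytotoxicity, read by CCK-8 assay, with a stated time of 72 h; on this read-out higher numbers stand for weaker inhibition and lower numbers for stronger inhibition. Within the data shown here, compound 1 is the only one for which a number is available: in this assay compound 1 gives 4600 nM. Among the measured compounds shown here, compound 2 was reported as "not active" (no number reported), and no number was given for it, so no step between the two can be stated beyond that one yields a value and the other does not.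

Compound 3 `C=CCn1c(=O)/c(=C\c2cc(F)ccc2C)[nH]c(=O)/c1=C\c1ccccc1OC` has not yet been measured in this assay. It differs from compound 1 in one place: 5-fluoro-2-methylphenyl in place of 3-chlorophenyl on a double-bonded chain carbon bound to an aromatic carbon. For the measured compounds named here, no measured pair isolates a change of this kind, so the direction of the step is uncertain. Given that compound 1 gives 4600 nM and that compound 2, the one other variant of this aryl group, returned no number, the expectation is a step of modest size toward weaker inhibition, with a wide range covering no change. The estimated step is a 1.5-fold higher number from compound 1 to compound 3 (0.18 log units; within the scatter). Compound 3 is expected to give about 7000 nM, within a range from 2000 nM to 30000 nM.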

Compound 3, half-maximal inhibitory concentration: 1600 nM
Compound 3: middle estimate off by 4.4-fold (0.64 log units), on the high side; the whole stated range lies above it.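

In this assay, the aryl group on a double-bonded chain carbon bound to an aromatic carbon now has its first readable step: 5-fluoro-2-methylphenyl in place of 3-chlorophenyl gives a 2.9-fold lower number from compound 1 to compound 3 (0.46 log units; beyond the scatter) and so moves toward stronger inhibition by a modest amount, beyond the usual scatter. Among these compounds, the earlier compounds showed only that one aryl group at this place gave a number while another gave none, and compound 3 adds that an aryl group without chlorine, carrying fluorine and methyl instead, also gives a number and a lower one than compound 1. No measurement shown here accounts for this gain.

The compounds shown leave open whether the lower number belongs to the fluorine, to the methyl or only to the two together, since a single step cannot separate them. They also leave open how this assay would respond to an amine or a carboxylic acid on this aryl ring, and whether the gain would hold with other groups elsewhere on the shared core.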